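Replacing the pyridine side chain with 2-methoxyethyl

The compounds below may be only part of what the source reports. "The series", "measured", "known", "first", "only" and "open" are said of these compounds alone.

In an ADME assay on MRC5 cells (Homo sapiens) for inhibition, with a stated time of 72 h (a lower number here means that less compound is needed, a higher number that more compound is needed for the effect), compound 1 `COc1cccc(OC)c1C(=O)Nc1c[nH]nc1C(=O)NCC1CCCCC1` gives > 50000 nM as a limit. In this assay compound 2 `COc1cccc(OC)c1C(=O)Nc1c[nH]nc1C(=O)NCc1ncccc1C` also gives > 50000 nM as a limit. Going by the values given here, the one measured step is a step that the two limits leave unreadable from compound 1 to compound 2 and offers no size to carry forward, and the limit of > 50000 nM in this assay, at which 2 of the 2 values shown sit, is all that bears on the next change. The change to compound 3 `COCCNC(=O)c1n[nH]cc1NC(=O)c1c(OC)cccc1OC` is methoxymethyl in place of 3-methylpyridin-2-yl on a saturated chain carbon bound to an amide-type nitrogen and puts methoxymethyl in place of 3-methylpyridin-2-yl on a saturated chain carbon bound to an amide-type nitrogen. The expected outcome is a number no higher from compound 2 to compound 3 (the limit leaves the size open) and no readable gain. In this assay the estimate for compound 3 is 50000 nM with an expected range of 20000 nM to 50000 nM and most likely only a limit.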

Compound 3, half-maximal effective concentration: > 50000 nM
Compound 3: a limit, no number; the forecaster's own chance of this, stated with the estimate: 85%; the middle value sits exactly at the limit.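

Going by these compounds alone, no step among compound 1, compound 2 and compound 3 can be read in this assay, as all three give only limits: the limit of > 50000 nM in this assay, at which 3 of the 3 values shown sit. The compounds shown leave open whether any of these side chains changes the concentration needed, and by how much.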